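Aryl-triazolyl oxindoles in an endothelial-cell inhibition assay

This account rests on a few compounds, and the source may have more. Where it says the series, first, only, none or still open, it means among the compounds named here.

Measured so far:
- compound 1, `N#Cc1cccc(-n2cc(-c3ccc(/C=C4\C(=O)Nc5ccccc54)cc3)nn2)c1`: in an ADME assay on HUVEC cells (Homo sapiens) for inhibition, read by CCK-8 assay, with a stated time of 24 h, in the presence of a further agent that is not named here (a lower number here means a stronger inhibitor, a higher number a weaker inhibitor), compound 1 gives > 20000 nM, which is a limit of the assay and not a number.
- compound 2, `O=C1Nc2ccccc2/C1=C/c1ccc(-c2cn(-c3ccc(Cl)c(C(F)(F)F)c3)nn2)cc1`: in this assay compound 2 gives > 20000 nM, again a limit.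
- compound 3, `N#Cc1cccc(-n2cc(-c3ccc(/C=C4\C(=O)Nc5ccc(F)cc54)cc3)nn2)c1`: in this assay compound 3 gives > 20000 nM, again a limit.

Compound 2 comes from compound 1 by 4-chloro-3-(trifluoromethyl)phenyl in place of 3-cyanophenyl on an aromatic nitrogen; the step that the two limits leave unreadable from compound 1 to compound 2 cannot be read because the limit of > 20000 nM in this assay, at which 3 of the 3 values shown sit, covers both ends. The two cores differ by fluoro in place of hydrogen on an aromatic carbon, and the step that the two limits leave unreadable from compound 1 to compound 3 is likewise unreadable for the same reason, (the limit of > 20000 nM in this assay, at which 3 of the 3 values shown sit).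

Not yet measured is compound 4, `O=C1Nc2ccc(F)cc2/C1=C/c1ccc(-c2cn(-c3ccc(Cl)c(C(F)(F)F)c3)nn2)cc1`. It differs from compound 3 by 4-chloro-3-(trifluoromethyl)phenyl in place of 3-cyanophenyl on an aromatic nitrogen, the same change as from compound 1 to compound 2, at the same place. Since that change left both ends at the limit, the expected step of a number no higher from compound 3 to compound 4 (the limit leaves the size open) in this assay rests only on this and is taken as flat. Compound 4 is therefore expected to give about 20000 nM in this assay, with a range of 12000 nM to 40000 nM, most likely reported as a limit again.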

Compound 4, half-maximal inhibitory concentration: > 20000 nM
Compound 4: a limit, no number; the forecaster's own chance of this, stated with the estimate: 85%; the middle value sits exactly at the limit.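

In this assay neither the step from compound 3 to compound 4 nor the step from compound 2 to compound 4 can be read, because each compound's result is a limit and not a number: the limit of > 20000 nM in this assay, at which 4 of the 4 values shown sit. The compounds shown leave open whether either change, the aryl group on the aromatic nitrogen or the fluoro on the core, alters inhibition, and how strong an inhibitor any of the four is.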